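The source may hold more compounds than are shown below. What is called first, only, known or untested is meant among the compounds shown, and "the series" means these compounds.

Measured in a functional assay on the whole organism for agonist activity, with Mus musculus as the target; on this read-out higher numbers stand for an effect only at larger amounts of compound and lower numbers for an effect already at smaller amounts:
- Compound 1 `CC(=O)N(C)C(C)C#CCn1cncc1C`: > 100 mg/kg, a limit of the assay and not a number
- Compound 2 `CC(=O)NCC#CCn1cncc1C`: 66 mg/kg
- Compound 3 `CC(=O)N(C)CC#CCn1ccnc1`: 1.4 mg/kg

Of the two true numbers, compound 3 has the lower, 1.4 mg/kg, so it acts at smaller doses, and compound 2 lies beyond the scatter above it. Compound 4 `CC(=O)N(C)CC#CCn1cncc1C` differs from compound 3 by methyl in place of hydrogen on an aromatic carbon. Among the measured compounds shown here, no measured pair isolates this change. Compound 2 carries the same methyl and gives 66 mg/kg, though it also differs from compound 4 elsewhere. A rise beyond the scatter is therefore expected, and the estimated change is an 8.6-fold higher number from compound 3 to compound 4 (0.93 log units; beyond the scatter). For compound 4 the expected value is 12 mg/kg, with an estimated range from 3 mg/kg to 60 mg/kg.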

Compound 4, dose for half-maximal effect: > 100 mg/kg
Compound 4 ended at the assay's limit; the forecaster's own chance of this, stated with the estimate: 10%; at least 8.3-fold (0.92 log units) between middle value and limit.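

Among the compounds shown here, no earlier pair isolated this change, and methyl in place of hydrogen on an aromatic carbon now gives an at least 71-fold higher number from compound 3 to compound 4 (1.85 log units; beyond the scatter), so this one added carbon costs a large loss of effect. Methyl in place of hydrogen on the amide-type nitrogen gives an at least 1.5-fold higher number from compound 2 to compound 4 (0.18 log units; that floor lies within the scatter), so with the ring methyl present, that second change has no readable effect. The step from compound 1 cannot be read, since both values are limits and not numbers: the limit of > 100 mg/kg in this assay, at which 2 of the 4 values shown sit.

The compounds shown leave open whether an ethyl group or a chlorine atom at this aromatic carbon would fare any better than methyl. They also leave open how far beyond the limit compound 4 lies.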